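The source may report more compounds than this note shows. Statements on the series, on what has been measured and on what is new or still open speak of the compounds shown alone.

Working notes on the series, read in a functional assay on MDA-MB-231 cells (Homo sapiens) for cytotoxicity, read by MTT assay, with a stated time of 72 h; a higher number here means a weaker inhibitor, a lower number a stronger inhibitor. Compound 3 `CN1CCCC1CCO/N=C1C(=C2/C(=O)Nc3ccccc32)/Nc2ccccc2/1` gives 250 nM and compound 2 `CN(C)CCCO/N=C1C(=C2/C(=O)Nc3ccccc32)/Nc2ccccc2/1` gives 440 nM, so these two stand together within the scatter. Differing from both in more than one place, compound 1 `CN1CCCCC1CCO/N=C1C(=C2/C(=O)Nc3ccccc32)/Cc2ccccc2/1` gives 1170 nM, a higher number that lies beyond the scatter from compound 3. Within the data shown here, compound 3 therefore sits at the low end of the numbers so far, level with compound 2.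

Next in line is compound 4 `CN1CCC(O/N=C2C(=C3/C(=O)Nc4ccccc43)/Nc3ccccc3/2)CC1`. The change is 1-methylpiperidin-4-yl in place of 2-(1-methylpyrrolidin-2-yl)ethyl on an oxygen, with 1-methylpiperidin-4-yl in place of 2-(1-methylpyrrolidin-2-yl)ethyl on an oxygen.

Among the measured compounds shown here, only one measured step bears on this, and only loosely: a 1.8-fold lower number from compound 2 to compound 3 (0.25 log units; within the scatter), which stays within the scatter. That step altered the group carried on the chain, while here the whole group on the oxygen is exchanged. For the measured compounds named here, the series holds no measured pair with this exact exchange, and compound 1 offers no clean comparison. In this assay, no large shift is therefore expected, only a slight lean towards a higher number. The expected step is a 1.6-fold higher number from compound 3 to compound 4 (0.20 log units; within the scatter). For compound 4 the estimated value is 400 nM, with an expected range of 150 nM to 1100 nM.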

Compound 4, half-maximal inhibitory concentration: 250 nM
Estimate against measurement, compound 4: 1.6-fold (0.20 log units) above; low and high end bracket the measured number.
By their numbers in this assay, from the lowest: compounds 3, 4 and 2 (each within the scatter of the next); then compound 1.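

In this assay, placing 1-methylpiperidin-4-yl on an oxygen whose other neighbours are double-bonded nitrogen gives no change at the digits printed from compound 3 to compound 4 (within the scatter) and a 1.8-fold lower number from compound 2 to compound 4 (0.25 log units; within the scatter). Replacing either 2-(1-methylpyrrolidin-2-yl)ethyl or 3-(dimethylamino)propyl with this group therefore produces no step beyond the scatter, so compounds 2, 3 and 4 form a level set on the shared core. Until now, the comparison on this core had covered only groups with an ethyl or propyl chain on the oxygen, whereas compound 4 shows that, for these three compounds, such a chain is not needed to stay at this level, and no measurement shown here offers an explanation for the result.

Going by these compounds, it remains open whether the level would hold with other groups on the oxygen, such as piperidin-4-yl without the methyl on its nitrogen, a morpholine ring at the end of a longer chain, or a chain ending in a carboxylic acid. On these data alone, compound 1 differs from these compounds in more than one place, so the part played by the core in its higher number also remains open.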